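The compounds below may be only part of what the source reports. "The series", "measured", "known", "first", "only" and "open" are said of these compounds alone.

Series notes, measured in a functional assay on K562 cells (Homo sapiens) for cytotoxicity, read by trypan blue exclusion, with a stated time of 96 h; on this read-out lower numbers stand for stronger inhibition and higher numbers for weaker inhibition:

- compound 1 `COC(=O)CCNc1cc(CS(=O)(=O)/C=C/c2c(OC)cc(OC)cc2OC)ccc1OC`: 1000 nM
- compound 2 `COC(=O)C(Nc1cc(CS(=O)(=O)/C=C/c2c(OC)cc(OC)cc2OC)ccc1OC)c1ccc(OC)cc1`: 150 nM
- compound 3 `COc1cc(OC)c(/C=C/S(=O)(=O)Cc2ccc(OC)c(NC(C(=O)O)c3ccc(F)cc3)c2)c(OC)c1`: 80 nM

Compound 3 sits at 80 nM, within the usual scatter of compound 2 at 150 nM, so no order can be drawn between these two. Compound 3 lies well clear of compound 1, as a 13-fold lower number from compound 1 to compound 3 (1.10 log units; beyond the scatter) shows.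

The next compound is compound 4 `COc1ccc(C(Nc2cc(CS(=O)(=O)/C=C/c3c(OC)cc(OC)cc3OC)ccc2OC)C(=O)O)cc1`, the carboxylic acid that differs from compound 3 at one place: methoxy in place of fluoro on an aromatic carbon. Methoxy replaces fluoro on an aromatic carbon, para to a large group.

For the measured compounds named here, only one measured step exists, a 13-fold lower number from compound 1 to compound 3 (1.10 log units; beyond the scatter). It is large, but it replaces the whole group on the nitrogen and so gives little guide to an exchange of this size. Going by the values given here, no measured step isolates fluoro against methoxy. The nearest evidence is compound 2 at 150 nM, which already carries the 4-methoxyphenyl group, though as a methyl ester and not as the free acid. Its value gives no sign that the 4-methoxyphenyl group is poorly tolerated in this assay.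

No step beyond the scatter is therefore expected, and neither direction is favoured with confidence. The expected change is a 1.1-fold higher number from compound 3 to compound 4 (0.05 log units; within the scatter). For compound 4 the estimated value is 90 nM, with an expected range of 30 nM to 270 nM.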

Compound 4, half-maximal inhibitory concentration: 15 nM
Compound 4: the middle estimate sits 6.0-fold (0.78 log units) above what was measured; measured number outside the range, below it.
By their numbers in this assay, from the lowest: compound 4; then compounds 3 and 2 (each within the scatter of the next); then compound 1.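

In this assay, for the compounds shown here, the exchange of fluoro for methoxy on this aromatic carbon, para to a large group, is not neutral: this is the first step to isolate the position, and it lies beyond the scatter (a 5.3-fold lower number from compound 3 to compound 4 (0.73 log units; beyond the scatter)). With 4-methoxyphenyl held constant, hydrogen in place of methyl on the oxygen next to the carbonyl group also counts, so the free carboxylic acid compound 4 stands clear of its methyl ester (a 10-fold lower number from compound 2 to compound 4 (1.00 log units; beyond the scatter)), and carboxy(4-methoxyphenyl)methyl in place of 2-(methoxycarbonyl)ethyl on the nitrogen gives the largest step in the series (a 67-fold lower number from compound 1 to compound 4 (1.82 log units; beyond the scatter)), which leaves compound 4 with the lowest number of the four. No independent measurement bears on what lies behind these steps.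

The compounds shown leave open whether chloro, hydroxy or an amine on this aromatic carbon would follow methoxy or fluoro, and whether a primary amide in place of the carboxylic acid would keep the number of compound 4. Also open, as far as these compounds go, is whether the step from methyl ester to carboxylic acid has the same size with 4-fluorophenyl as with 4-methoxyphenyl.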